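The source may hold more compounds than are shown below. What is called first, only, known or untested is meant among the compounds shown, and "the series" means these compounds.

Working notes on the series. Compound 1 `CC1(C)C=C(n2ccccc2=O)c2cc(OS(=O)(=O)F)ccc2O1` gives 7.22 in a functional assay (trachea) with Rattus norvegicus as the target; on this read-out higher numbers stand for higher potency (the scale is a negative logarithm) and lower numbers for lower potency. Within the data shown here, compound 2 `CC1(C)C=C(n2ccccc2=O)c2cc(C(=N)S)ccc2O1` gives 5.96 in this assay and stands lowest of the two numbers in hand, its only neighbour being compound 1; the single measured step is a number 1.26 log units lower from compound 1 to compound 2 (beyond the scatter). Compound 3 `CC1(C)C=C(n2ccccc2=O)c2cc(C(F)(F)F)ccc2O1` is the next member. It differs from compound 2 by a group of 4 heavy atoms (1 carbon, 3 fluorine; no ring) in place of a group of 3 heavy atoms (1 carbon, 1 nitrogen, 1 sulfur; no ring), on an aromatic carbon, the change sitting on an aromatic carbon of a six-membered aromatic ring of carbon only, part of a fused or bridged system of two rings, meta to a fused ring and para to a fused ring. Among the measured compounds shown here, the only measured step that bears on this carbon is a number 1.26 log units lower from compound 1 to compound 2 (beyond the scatter), a large one, so what stands at this position matters in this assay. For the measured compounds named here, no measured compound carries a trifluoromethyl, so the direction rests solely on compound 1 reaching the higher number 7.22 with a different group in the same place. An upward step beyond the scatter is therefore expected, though not of the full size of a number 1.26 log units lower from compound 1 to compound 2 (beyond the scatter). For compound 3 the estimate in this assay is 6.7, within 6 to 7.4. The expected step is a number 0.74 log units higher from compound 2 to compound 3 (beyond the scatter).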

Compound 3, logarithm of the reciprocal of the active concentration, log(1/C): 7.37
The estimate for compound 3 lay 0.67 log units below the measured number; the range from low to high includes it.
By their numbers in this assay, from the lowest: compound 2; then compounds 1 and 3 (each within the scatter of the next).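

In this assay the two groups at this aromatic carbon, trifluoromethyl and (fluorosulfonyl)oxy, cannot be told apart, with a number 0.15 log units higher from compound 1 to compound 3 (within the scatter). Together with the large a number 1.41 log units higher from compound 2 to compound 3 (beyond the scatter), this places the low number of compound 2 with its own group rather than with the shared core, at least among these three compounds. Among these compounds, the earlier single step showed only that the group at this carbon matters; now two groups made of different atoms are seen to give numbers within the scatter of each other, so a high number here does not depend on one particular group. Nothing measured here bears on why the numbers at this carbon fall as they do.

Still open, on these data alone, is how an amine, a carboxylic acid or a plain methyl would read at this carbon, and whether any group would go clearly beyond the level shared by compound 1 and compound 3. Also open, as far as these compounds go, is whether these groups would keep the same order on a changed core, since all three compounds share one core and one read-out.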